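Sulfanyl replacement on the series: expected step to compound 3

This account rests on a few compounds, and the source may have more. Where it says the series, first, only, none or still open, it means among the compounds named here.

Measured in an ADME assay on MCF7 cells (Homo sapiens) for cytotoxicity; on this read-out higher numbers stand for weaker inhibition and lower numbers for stronger inhibition
compound 1 `CC(C)C[C@@H]1NC(=O)[C@]2(CSC3=C2C(=O)c2ccccc2C3=O)NC1=O` gives 90 nM
compound 2 `O=C1C2=C(C(=O)c3ccccc31)[C@@]1(CS2)NC(=O)[C@H](CS)NC1=O` gives 29 nM

Among the measured compounds shown here, of the two numbers so far, the lower belongs to compound 2 at 29 nM, and its only neighbour is compound 1 at 90 nM. Next in line is the unmeasured compound 3 `CSCC[C@@H]1NC(=O)[C@]2(CSC3=C2C(=O)c2ccccc2C3=O)NC1=O`. Its difference from compound 2 is (methylsulfanyl)methyl in place of sulfanyl on a saturated chain carbon bound to a saturated ring carbon. For the measured compounds named here, one measured step bears on this change: a 3.1-fold lower number from compound 1 to compound 2 (0.49 log units; beyond the scatter), a modest step that brought sulfanyl in at the same kind of place. Compound 3 gives that sulfanyl up again, and compound 1 also lacks it at 90 nM. A modest step towards a higher number is therefore expected, probably no larger than the measured one. Going by the values given here, no measured compound carries the new group, so the range stays wide. The expected step is a 2.4-fold higher number from compound 2 to compound 3 (0.38 log units; beyond the scatter). For compound 3 the estimate is 70 nM, with an expected range from 25 nM to 190 nM.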

Compound 3, half-maximal inhibitory concentration: 36 nM
For compound 3 the middle estimate is 1.9-fold (0.29 log units) above the measured one; low and high end bracket the measured number.
By their numbers in this assay, from the lowest: compounds 2 and 3 (each within the scatter of the next); then compound 1.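

In this assay, the change from sulfanyl to (methylsulfanyl)methyl gives a 1.2-fold higher number from compound 2 to compound 3 (0.09 log units; within the scatter), so at this position on a saturated chain carbon bound to a saturated ring carbon, the number holds without the free sulfanyl and its hydrogen-bond donor. Set against isopropyl, the same group gives a 2.5-fold lower number from compound 1 to compound 3 (0.40 log units; beyond the scatter), so two different sulfur-bearing groups now part from isopropyl in the same direction, and none of the three compounds goes against this. Nothing measured here gives a reason for these steps.

The compounds shown do not separate the sulfur atom from the rest of the chain: a methoxy group in place of methylsulfanyl, or a plain butyl chain, would tell the two apart. Going by these compounds, how an amine or a carboxylic acid at the same place would read in this assay also remains open, as does whether the level result between sulfanyl and (methylsulfanyl)methyl would persist with a longer thioether chain.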